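The compounds below may be only part of what the source reports. "The series", "measured", "known", "first", "only" and "open" are said of these compounds alone.

Compound 1 `COC[C@H](C)[C@@H](C)C(c1ccc(O)c(OC)c1)c1ccc(O)c(OC)c1`: 68000 nM
Compound 2 `CCCCCCCC[C@H](C(C)C)C(c1ccc(O)c(OC)c1)c1ccc(O)c(OC)c1`: 3700 nM

In a functional assay on HL-60 cells (Homo sapiens) for cytotoxicity, read by WST assay, with a stated time of 48 h (a higher number here means a weaker inhibitor, a lower number a stronger inhibitor), compound 2 has the lower number of the two and so is the stronger inhibitor, and its gap to compound 1 lies beyond the scatter. Compound 3 `CCCCC[C@H](C(C)C)C(c1ccc(O)c(OC)c1)c1ccc(O)c(OC)c1` has not yet been measured. It differs from compound 2 in one place: hydrogen in place of propyl on a saturated chain carbon, seven bonds along the chain from two aromatic carbons, with hydrogen in place of propyl on a saturated chain carbon, seven bonds along the chain from two aromatic carbons. Among the compounds with values here, no measured pair differs in just one place, so the size of this step can only be judged indirectly. Compound 1, without the long chain, gives 68000 nM, against 3700 nM for compound 2. A moderate rise in the number, meaning a weaker inhibitor, is therefore expected, probably just beyond the scatter. The expected change is a 3.0-fold higher number from compound 2 to compound 3 (0.47 log units; beyond the scatter). The estimated value for compound 3 is 11000 nM, with an expected range of 4500 nM to 30000 nM.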

Compound 3, half-maximal inhibitory concentration: 9600 nM
Estimate against measurement, compound 3: 1.1-fold (0.06 log units) above, and the stated range covers the measured number.
By their numbers in this assay, from the lowest: compound 2; then compound 3; then compound 1.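

In this assay, within the data shown here, hydrogen in place of propyl on a saturated chain carbon, seven bonds along the chain from two aromatic carbons, gives a 2.6-fold higher number from compound 2 to compound 3 (0.41 log units; beyond the scatter) and so provides the first direct reading of this position: removing this part of the chain weakens the compound, but only modestly. The remaining 1-isopropylhexyl group still outperforms the 2-(methoxymethyl)-1-methylpropyl group at the saturated chain carbon bound to two aromatic carbons, with a 7.1-fold lower number from compound 1 to compound 3 (0.85 log units; beyond the scatter) for that exchange. The data shown offer no explanation for either step.

Going by these compounds, whether a still longer chain would lower the number further, or whether the effect would level off, remains open. It is also unknown how the number would respond to an amine or a carboxylic acid at the end of the chain.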